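The source may hold more compounds than are shown below. What is called first, only, known or untested is meant among the compounds shown, and "the series" means these compounds.

Compound 1 `CCCSc1nc(N/N=C/c2ccc(C)cc2)c2nnn(Cc3ccccc3)c2n1` was tested in a functional assay on ECa-109 cells (Homo sapiens) for antiproliferative activity, read by MTT assay, with a stated time of 72 h; on this read-out higher numbers stand for weaker inhibition and lower numbers for stronger inhibition. There compound 1 reached only the limit of > 64000 nM, so no number is known for it. Compound 2 `CCCSc1nc(N/N=C(\C)c2ccccc2O)c2nnn(Cc3ccccc3Cl)c2n1` likewise stopped at the limit, giving > 64000 nM in this assay. Both results share (the limit of > 64000 nM in this assay, at which 2 of the 2 values shown sit). Compound 3 `CCCSc1nc(N/N=C(\C)c2ccccc2)c2nnn(Cc3ccccc3)c2n1` is still to be measured; it differs from compound 1 by a group of 9 heavy atoms (8 carbon, 1 nitrogen; one six-membered aromatic ring of carbon only) in place of a group of 9 heavy atoms (8 carbon, 1 nitrogen; one six-membered aromatic ring of carbon only), on a nitrogen on an aromatic ring. Among the measured compounds shown here, no step between measured compounds is available, so a step that the limit leaves unreadable from compound 1 to compound 3 is expected, one that stays within the scatter. Compound 3 is therefore expected to give about 80000 nM in this assay, between 30000 nM and 200000 nM, most likely again as a limit.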

Compound 3, half-maximal inhibitory concentration: 32200 nM
The estimate for compound 3 lay 2.5-fold (0.40 log units) above the measured number; low and high end bracket the measured number.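

In this assay compound 3 gives the first actual number among the compounds shown, 32200 nM, so this position can carry a group that yields a readable value. Joining the same atoms differently in the group on a nitrogen on an aromatic ring gives an at least 1.9-fold lower number from compound 1 to compound 3 (0.29 log units; that floor lies within the scatter), so a real difference between the two is not established. The comparison remains open-ended on one side: the limit of > 64000 nM in this assay, at which 2 of the 3 values shown sit.

As far as these compounds go, it remains open what an amine or a carboxylic acid on the six-membered aromatic ring of this group would give in this assay.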